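Urea series: extending the aryl urea toward a carbazide

The compounds below may be only part of what the source reports. "The series", "measured", "known", "first", "only" and "open" are said of these compounds alone.

Measured compounds in a functional assay on SW-620 cells (Homo sapiens) for inhibition, read by MTT assay, with a stated time of 72 h; on this read-out lower numbers stand for stronger inhibition and higher numbers for weaker inhibition:
- compound 1 `COc1cc(NC(C)CCCNC(=O)Nc2ccc(F)cc2)c2ncccc2c1`: 25000 nM
- compound 2 `COc1cc(NC(C)CCCNC(=O)Nc2ccc(C(F)(F)F)cc2)c2ncccc2c1`: 22000 nM
- compound 3 `COc1cc(NC(C)CCCNC(=O)Nc2ccc(O)cc2)c2ncccc2c1`: 30000 nM

Compound 3 gives the highest of the three numbers, yet a 1.2-fold higher number from compound 1 to compound 3 (0.08 log units; within the scatter) and a 1.4-fold higher number from compound 2 to compound 3 (0.13 log units; within the scatter) both stay within the scatter, as does a 1.1-fold lower number from compound 1 to compound 2 (0.06 log units; within the scatter); the three values are indistinguishable. Compound 4 `COc1cc(NC(C)CCCNC(=O)NNC(=O)Nc2ccc(O)cc2)c2ncccc2c1` carries ((4-hydroxyphenyl)carbamoyl)amino in place of 4-hydroxyphenyl on an amide-type nitrogen. Among the compounds with values here, no measured step touches this position: all three steps so far vary only the aromatic substituent and leave the linker untouched, so none bears on the change. With the set this flat and nothing to indicate a direction, no step beyond the scatter is expected for no change at the digits printed from compound 3 to compound 4 (within the scatter). Compound 4 is estimated at 30000 nM, with a range of 12000 nM to 75000 nM.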

Compound 4, half-maximal inhibitory concentration: > 100000 nM
Compound 4 ended at the assay's limit; the forecaster's own chance of this, stated with the estimate: 20%; middle value at least 3.3-fold (0.52 log units) from the limit.
By their numbers in this assay, from the lowest: compounds 2, 1 and 3 (each within the scatter of the next). At a limit, above all of these: compound 4.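

In this assay, the amide-type nitrogen proves sensitive where the aromatic substituent did not: the ((4-hydroxyphenyl)carbamoyl)amino group gives an at least 3.3-fold higher number from compound 3 to compound 4 (0.52 log units; beyond the scatter). The other two steps agree, with an at least 4.5-fold higher number from compound 2 to compound 4 (0.65 log units; beyond the scatter) and an at least 4.0-fold higher number from compound 1 to compound 4 (0.60 log units; beyond the scatter), so all three comparisons point to weaker inhibition. The value of compound 4 is a limit and not a number: the limit of > 100000 nM in this assay, at which 1 of the 4 values shown sits.

Going by these compounds, how much weaker compound 4 really is stays open. Also open, on these data alone, is whether a simple amine or a longer carbon chain at this nitrogen would be tolerated, and whether fluoro or trifluoromethyl on the extended group would read differently.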